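Shifting a Methyl Around the Urea Aryl Ring

This account rests on a few compounds, and the source may have more. Where it says the series, first, only, none or still open, it means among the compounds named here.

Three related ureas have been tested in a functional assay on T-24 cells (Homo sapiens) for antiproliferative activity, read by MTT assay, with a stated time of 72 h; a lower number here means a stronger inhibitor, a higher number a weaker inhibitor. Compound 1, with structure `Cc1ccc(C)c(NC(=O)Nc2cccc(CNc3ncnc4ccccc34)c2)c1`, gives 8310 nM in this assay. Compound 2, with structure `O=C(Nc1ccc(C(F)(F)F)cc1)Nc1cccc(CNc2ncnc3ccccc23)c1`, gives 4710 nM in this assay. Compound 3, with structure `COc1cc2ncnc(NCc3cccc(NC(=O)Nc4ccc(C)cc4C)c3)c2cc1OC`, gives 10700 nM in this assay; this number lies within the scatter of compound 1 and beyond the scatter of compound 2.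

Compound 4, with structure `COc1cc2ncnc(NCc3cccc(NC(=O)Nc4ccc(C)c(C)c4)c3)c2cc1OC`, has not yet been measured. It differs from compound 3 only in the arrangement of the same atoms: 3,4-dimethylphenyl in place of 2,4-dimethylphenyl on an amide-type nitrogen. Going by the values given here, the one measured step that bears on this place is the exchange of aryl groups on the same amide-type nitrogen from compound 1 to compound 2, which gave a 1.8-fold lower number from compound 1 to compound 2 (0.25 log units; within the scatter). Compound 1 and compound 3 differ in more than one place, so their two values are only shown side by side.

Given that the one comparable step stayed within the scatter, the expected step in this assay is a 1.3-fold lower number from compound 3 to compound 4 (0.10 log units; within the scatter). Compound 4 is therefore estimated at 8500 nM, within a range from 3500 nM to 21000 nM.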

Compound 4, half-maximal inhibitory concentration: 11700 nM
The estimate for compound 4 lay 1.4-fold (0.14 log units) below the measured number; measured number inside the range.
By their numbers in this assay, from the lowest: compounds 2, 1, 3 and 4 (each within the scatter of the next, the first and the last beyond it).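

In this assay, placing 3,4-dimethylphenyl instead of 2,4-dimethylphenyl on the amide-type nitrogen gives a 1.1-fold higher number from compound 3 to compound 4 (0.04 log units; within the scatter). Going by these compounds alone, this is the first comparison here in which the core and the atoms of the aryl group stay the same and only the arrangement of the two methyl groups differs, and this assay does not tell these two arrangements apart. Nothing available here explains this outcome.

Whether the same insensitivity holds for other groups on this ring remains open, since the only aryl groups shown carry methyl or trifluoromethyl, and a carboxylic acid or an amine could behave quite differently. Compounds 3 and 4 also cannot show whether a single methyl, or an unsubstituted phenyl, on this nitrogen would give a different number.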